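The compounds below may be only part of what the source reports. "The series", "measured", "known", "first", "only" and "open" are said of these compounds alone.

Measured so far in a functional assay on MCF7 cells (Homo sapiens) for inhibition, read by XTT assay, with a stated time of 48 h; a lower number here means a stronger inhibitor, a higher number a weaker inhibitor:

- compound 1, `COc1ccc(C(=O)/C(=C/c2ccc(Cl)cc2Cl)CC(C)C)cc1` — > 100000 nM
- compound 2, `COc1ccc(C(=O)/C(=C/c2ccc([N+](=O)[O-])cc2)CC(C)C)cc1` — > 100000 nM

Compound 2 shows only a limit of this assay, > 100000 nM, and no number. Compound 1 likewise reaches only a limit, > 100000 nM. Among the compounds with values here, the shared core is therefore without a single resolved value; both compounds sit at the limit of > 100000 nM in this assay, at which 2 of the 2 values shown sit, so no step between measured compounds can be stated and no direction is set.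

The next compound, compound 3, `COc1ccc(C(=O)/C(=C/c2ccc(Cl)cc2)CC(C)C)cc1`, differs from compound 2 by chloro in place of nitro on an aromatic carbon. With compound 1 also at its limit and carrying a chloro group among other substituents, nothing in the shown values points to a gain in potency from this exchange. The expected step from compound 2 to compound 3 is a step that the limit leaves unreadable from compound 2 to compound 3, that is none beyond the scatter. Compound 3 is estimated at 150000 nM, within 50000 nM to 500000 nM, with a strong likelihood that this assay again reports only a limit.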

Compound 3, half-maximal inhibitory concentration: > 100000 nM
Compound 3 gave a limit, no number (the forecaster's own chance of this, stated with the estimate: 80%); the middle value does not contradict the limit.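

Like compound 1 and compound 2, compound 3 reaches only a limit in this assay and gives no number, so no new step can be read among these compounds. The compounds shown leave open which change to the shared core, if any, would give a resolved value in this assay at all.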